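Swapping an Aromatic Ring for a Saturated One

The source may report more compounds than this note shows. Statements on the series, on what has been measured and on what is new or still open speak of the compounds shown alone.

Three compounds share one core and differ only in the group on the carbonyl carbon of the amide. Compound 1 `CCOC(=O)c1sc(-c2cccc(NC(=O)c3ccc(C(F)(F)F)cc3)c2)nc1Nc1ccc(N2CCN(C)CC2)cc1` gives 33% in a functional assay on Raji cells (Homo sapiens) for antiproliferative activity, read by CCK-8 assay, with a stated time of 72 h, tested at 40 uM; a higher number here means more inhibition at the concentration tested (going by the name of the read-out), a lower number less inhibition. Compound 3 `CCOC(=O)c1sc(-c2cccc(NC(=O)c3ccc(C(F)(F)F)cn3)c2)nc1Nc1ccc(N2CCN(C)CC2)cc1` gives 20.8%. Compound 2 `CCOC(=O)c1sc(-c2cccc(NC(=O)c3ccc(C(C)(C)C)cc3)c2)nc1Nc1ccc(N2CCN(C)CC2)cc1` gives 4.22%, the lowest of the three values; the step of a number 28.8 percentage points lower from compound 1 to compound 2 (beyond the scatter) and the step of a number 16.6 percentage points higher from compound 2 to compound 3 (beyond the scatter) both lie beyond the scatter. Compound 4 `CCOC(=O)c1sc(-c2cccc(NC(=O)[C@H]3CC[C@H](C)CC3)c2)nc1Nc1ccc(N2CCN(C)CC2)cc1` carries the change (4-methylcyclohexyl in place of 4-(tert-butyl)phenyl on a carbonyl carbon). For the measured compounds named here, no measured step brings a non-aromatic ring to this position, so the only guide is that compound 2 sits lowest and that each measured change of this group away from it rose, as in a number 16.6 percentage points higher from compound 2 to compound 3 (beyond the scatter). A modest rise is therefore expected, a number 9.8 percentage points higher from compound 2 to compound 4 (within the scatter). For compound 4 an estimated 14% is expected, probably between 0% and 32%.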

Compound 4, a percentage reported as inhibition, at one concentration (the size of the read-out at that concentration, not a potency): 26.1%
Compound 4: middle estimate off by 12.1 percentage points, on the low side; the range from low to high includes it.
By their numbers in this assay, from the lowest: compound 2; then compounds 3, 4 and 1 (each within the scatter of the next, the first and the last beyond it).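

In this assay, this position accepts a saturated ring: 4-methylcyclohexyl in place of 4-(tert-butyl)phenyl gives a number 21.9 percentage points higher from compound 2 to compound 4 (beyond the scatter). Set against the two trifluoromethyl-bearing groups, the saturated ring cannot be told apart, with a number 5.3 percentage points higher from compound 3 to compound 4 (within the scatter) and a number 6.9 percentage points lower from compound 1 to compound 4 (within the scatter). Nothing available explains the rise from the tert-butyl compound.

This change alters both ring type and group size, so a 4-methylphenyl group would be needed to separate the two. On these data alone, a plain cyclohexyl group and a piperidine ring, which carries an amine, also remain open.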